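A few compounds are considered here, and "the series" means these few. Any claim that something is new, unique, unknown or untested is made for them only; others in the source may bear on it.

Measured values in an assay for inhibition of 6-phosphofructo-2-kinase/fructose-2,6-bisphosphatase 3 (Homo sapiens), read by ADP-Glo, with a stated time of 2 h; a lower number here means a stronger inhibitor, a higher number a weaker inhibitor:

compound 1 `CN(C)C(=O)c1ccncc1Nc1cc(-c2ccc3ccn(C)c3c2)c2nccnc2c1`: 499 nM
compound 2 `CN1CC(NC(=O)c2ccncc2Nc2cc(-c3ccc4ccn(C)c4c3)c3nccnc3c2)C1`: 30 nM
compound 3 `CN1CCC(CNC(=O)c2ccncc2Nc2cc(-c3ccc4ccn(C)c4c3)c3nccnc3c2)C1`: 74 nM

Compound 3 stands second of the three: the number for compound 3 is a 2.5-fold higher number from compound 2 to compound 3 (0.39 log units; beyond the scatter) and a 6.7-fold lower number from compound 1 to compound 3 (0.83 log units; beyond the scatter). The shared core is kept in all three; the amide substituent on the carbonyl carbon is the only variable. Compound 4 `CC(=O)N1CCC(NC(=O)c2ccncc2Nc2cc(-c3ccc4ccn(C)c4c3)c3nccnc3c2)C1` continues this, with the change (1-acetylpyrrolidin-3-yl in place of (1-methylpyrrolidin-3-yl)methyl on an amide-type nitrogen). Going by the values given here, no measured step covers this exchange directly. The steps that touch the same position are a 17-fold lower number from compound 1 to compound 2 (1.22 log units; beyond the scatter) and a 6.7-fold lower number from compound 1 to compound 3 (0.83 log units; beyond the scatter), both toward lower numbers when a methyl-bearing ring amine replaces dimethylamino, and a 2.5-fold higher number from compound 2 to compound 3 (0.39 log units; beyond the scatter), a smaller effect from the ring and linker alone. Compound 4 loses the methyl-bearing ring nitrogen that compound 2 and compound 3 share, and replaces it with an acetyl-bearing one; on the pattern of compound 1, a move back toward a higher number is expected, though compound 1 also lacks the ring. The estimated step is a 3.0-fold higher number from compound 3 to compound 4 (0.47 log units; beyond the scatter). Compound 4 is expected at 220 nM, with a range from 60 nM to 800 nM.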

Compound 4, half-maximal inhibitory concentration: 105 nM
The estimate for compound 4 lay 2.1-fold (0.32 log units) above the measured number; the measured number falls inside the stated range.
By their numbers in this assay, from the lowest: compound 2; then compounds 3 and 4 (each within the scatter of the next); then compound 1.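

Working from this assay, the ring nitrogen of this amide substituent need not carry a methyl: 1-acetylpyrrolidin-3-yl in place of (1-methylpyrrolidin-3-yl)methyl gives a 1.4-fold higher number from compound 3 to compound 4 (0.15 log units; within the scatter), and the comparison with dimethylamino still gives a 4.8-fold lower number from compound 1 to compound 4 (0.68 log units; beyond the scatter). The 1-methylazetidin-3-yl of compound 2 remains apart from the acetyl-bearing substituent, with a 3.5-fold higher number from compound 2 to compound 4 (0.54 log units; beyond the scatter). No measurement shown here explains these results, and the exchange from compound 3 to compound 4 alters both the group on the ring nitrogen and the link to the amide-type nitrogen.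

Going by these compounds, the separate contributions of those two alterations remain open, as 1-methylpyrrolidin-3-yl attached directly to the amide-type nitrogen would be needed to divide them. Also open, on these data alone, is how 1-acetylazetidin-3-yl, or a ring bearing a free secondary amine, would read in this assay.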